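An oxime ether in place of an oxime on the shared core

A few compounds are considered here, and "the series" means these few. Any claim that something is new, unique, unknown or untested is made for them only; others in the source may bear on it.

Going by the values given here, compound 1 `CC(=O)/C(=N\O)c1ccc(Sc2cc(F)cc(C3CCOCC3)c2)cc1` is one of two compounds measured in a functional assay (blood) for inhibition, with Homo sapiens as the target (a lower number here means a stronger inhibitor, a higher number a weaker inhibitor), and compound 1 gives 850 nM, the highest of the two numbers. Compound 2 `CO/N=C(\C)c1ccc(Sc2cc(F)cc([C@@]3(OC)CCO[C@@H](C)C3)c2)cc1`, which differs from it in several places, gives 140 nM, a number beyond the scatter below that of compound 1. Compound 3 `C/C(=N\OCC#N)c1ccc(Sc2cc(F)cc(C3CCOCC3)c2)cc1` has not been measured; it differs from compound 1 by a group of 7 heavy atoms (4 carbon, 2 nitrogen, 1 oxygen; no ring) in place of a group of 6 heavy atoms (3 carbon, 1 nitrogen, 2 oxygen; no ring), on an aromatic carbon. Among the compounds with values here, no measured pair isolates this change, so the expected step is a 2.4-fold lower number from compound 1 to compound 3 (0.39 log units; beyond the scatter), a moderate move to a lower number near the edge of the scatter. Compound 3 is therefore estimated at 350 nM, within 90 nM to 1400 nM.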

Compound 3, half-maximal inhibitory concentration: 20 nM
Beside the measured number, compound 3's estimate is 18-fold (1.24 log units) above it, and the stated range ends above it.
By their numbers in this assay, from the lowest: compound 3; then compound 2; then compound 1.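

At this position, on an aromatic carbon para to a large group, the swap of the whole group gives a 43-fold lower number from compound 1 to compound 3 (1.63 log units; beyond the scatter) in this assay, a large step on the shared core. It shows that this place alone can move the number far, and that the group entering here, with 0 hydrogen-bond donors against 1 in the group that leaves, is compatible with strong inhibition. Nothing available accounts for the size of this step. The compounds shown do not separate the contribution of the nitrile end from that of the lost carbonyl. As far as these compounds go, how an amine or a longer chain would fare here also stays open.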